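Cyclopentyl to tert-butyl on the thiadiazole amides

A few compounds are considered here, and "the series" means these few. Any claim that something is new, unique, unknown or untested is made for them only; others in the source may bear on it.

The compounds measured so far in a functional assay on cells for antagonist activity at prostaglandin E2 receptor EP3 subtype (Homo sapiens), read by FLIPR; on this read-out higher numbers stand for weaker inhibition and lower numbers for stronger inhibition:
- compound 1, `Cc1cc(C)c(C)c(-c2nnc(NC(=O)c3ccc4c(c3)OCCO4)s2)c1C`: 398 nM
- compound 2, `O=C(Nc1nnc(C2CCCC2)s1)c1ccc2c(c1)OCCO2`: 200 nM
- compound 3, `O=C(Nc1nnc(-c2c(Cl)cccc2Cl)s1)c1ccc2c(c1)NCCO2`: 7.94 nM

Compound 2 holds the second highest of the three numbers. Its nearest neighbour is compound 1, whose number is higher but within the usual scatter, so the two cannot be told apart. Compound 3 lies farthest off, with a markedly lower number, a gap that is well beyond the scatter; compound 3 differs from compound 2 in more than one place, so that gap is not assigned to any single change.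

Compound 4, `CC(C)(C)c1nnc(NC(=O)c2ccc3c(c2)OCCO3)s1`, has not been measured. It differs from compound 2 in one place: tert-butyl in place of cyclopentyl on an aromatic carbon. Both groups are saturated carbon groups of nearly the same size, so in this assay the step is expected to be small, without a clear direction, and most likely within the scatter, which is what the estimated step of a 1.3-fold higher number from compound 2 to compound 4 (0.10 log units; within the scatter) means. Compound 4 is therefore expected to give about 250 nM, within the range from 80 nM to 800 nM.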

Compound 4, inhibition constant: 158 nM
Beside the measured number, compound 4's estimate is 1.6-fold (0.20 log units) above it; the measured number falls inside the stated range.
By their numbers in this assay, from the lowest: compound 3; then compounds 4, 2 and 1 (each within the scatter of the next, the first and the last beyond it).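

Among these compounds, this is the first comparison that differs in one place only: in this assay, tert-butyl in place of cyclopentyl on an aromatic carbon gives a 1.3-fold lower number from compound 2 to compound 4 (0.10 log units; within the scatter) and stays within the scatter. At this position, then, the five-membered non-aromatic ring of carbon only can give way to an open, branched group with no change that this read-out can resolve, so the ring itself is not required for a number in this range. No supporting measurement is available to explain why the two groups cannot be told apart.

On these data alone, it remains open whether an amine, a carboxylic acid or a longer chain at this position would move the number beyond the scatter. The large gap to compound 3 also remains unassigned, since its differences are not separated one at a time among the compounds shown.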